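The compounds below may be only part of what the source reports. "The series", "measured", "known", "first", "only" and "open" are said of these compounds alone.

Measured so far:
Compound 1 `O=C(CCc1cccc2c1B(O)OC2)Nc1ccccc1`: 200 nM
Compound 2 `O=C(CCc1cccc2c1B(O)OC2)Nc1cccc(-c2ccccc2)c1`: 250 nM
Compound 3 `O=C(CCc1cccc2c1B(O)OC2)Nc1cccc(-c2ccc(Cl)cc2)c1`: 220 nM

All three were tested in a functional assay on SK-OV-3 cells (Homo sapiens) for antiproliferative activity, read by MTT assay, with a stated time of 72 h; on this read-out higher numbers stand for weaker inhibition and lower numbers for stronger inhibition. On these numbers, compound 3 at 220 nM cannot be told apart from the other two, since its value lies within the scatter of both compound 1 and compound 2.

Compound 4 `COc1ccc(-c2cccc(NC(=O)CCc3cccc4c3B(O)OC4)c2)cc1` has not yet been measured. It differs from compound 3 in one group: methoxy in place of chloro on an aromatic carbon. This is methoxy in place of chloro on an aromatic carbon, para to a large group, so 4-chlorophenyl becomes 4-methoxyphenyl.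

For the measured compounds named here, no measured step makes this exchange directly, and no compound so far carries methoxy. The closest evidence is a 1.1-fold lower number from compound 2 to compound 3 (0.06 log units; within the scatter), where chloro replaces hydrogen. Two further steps bear on the same part of the molecule: a 1.3-fold higher number from compound 1 to compound 2 (0.10 log units; within the scatter) and a 1.1-fold higher number from compound 1 to compound 3 (0.04 log units; within the scatter). All three lie within the scatter, so none of them gives a reason to expect a real difference in this assay, in either direction. The expected step is a 1.0-fold higher number from compound 3 to compound 4 (0.02 log units; within the scatter), which would be nothing beyond the scatter. For compound 4 the estimated value is 230 nM, with an expected range from 120 nM to 450 nM.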

Compound 4, half-maximal inhibitory concentration: 48 nM
The estimate for compound 4 lay 4.8-fold (0.68 log units) above the measured number, and the stated range ends above it.
By their numbers in this assay, from the lowest: compound 4; then compounds 1, 3 and 2 (each within the scatter of the next).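

In this assay, this end of the molecule had so far shown no response: neither phenyl nor 4-chlorophenyl moved the number beyond the scatter from that of compound 1, whereas 4-methoxyphenyl gives a 4.2-fold lower number from compound 1 to compound 4 (0.62 log units; beyond the scatter). The change therefore rests on the methoxy group and not on the added phenyl alone, since methoxy in place of hydrogen gives a 5.2-fold lower number from compound 2 to compound 4 (0.72 log units; beyond the scatter) and methoxy in place of chloro gives a 4.6-fold lower number from compound 3 to compound 4 (0.66 log units; beyond the scatter), while hydrogen and chloro at this same place, para to a large group, cannot be told apart. Nothing among the data shown accounts for the difference between methoxy and chloro here.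

Going by these compounds, with only hydrogen, chloro and methoxy compared at this place, it remains open whether an ethoxy group, a hydroxyl group or a dimethylamino group would follow methoxy or stay with chloro and hydrogen. On these data alone, it is also open whether a methoxy group would give a similar step at another place on the same ring, or on compounds with a different chain to the core.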